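This account rests on a few compounds, and the source may have more. Where it says the series, first, only, none or still open, it means among the compounds named here.

Measured so far in an ADME assay on a cell-free system (plasma, Mus musculus, strain C57BL/6) for metabolic stability, read by HPLC, with a stated time of 12 h; on this read-out lower numbers stand for a shorter-lived compound and higher numbers for a longer-lived compound:
- Compound 1 `O=C(O)[C@@H](CO)NC(=O)[C@H]1C[C@H](O)CN1`: > 12 h
- Compound 2 `O=C(O)[C@H](CO)NC(=O)[C@H]1C[C@@H](O)CN1`: > 12 h

Each of these entries is a limit of the assay and not a number.

Compound 2 therefore has no exact position: its > 12 h is a limit. Compound 3 `O=C(O)[C@H](CO)NC(=O)[C@@H]1C[C@H](O)CN1` keeps the same atoms and bonds: the two compounds have the same atoms and bonds and differ only in configuration as drawn: 2 of 3 stereo elements differ; a stereocentre at a saturated ring carbon is drawn R in compound 2 and S in compound 3; a stereocentre at a saturated ring carbon is drawn R in compound 2 and S in compound 3. Within the data shown here, the only measured step, a step that the two limits leave unreadable from compound 1 to compound 2, also changes configuration alone (the fact that compounds 1 and 2 differ only in the configuration as drawn). It offers no size to carry over because of the limit of > 12 h in this assay, at which 2 of the 2 values shown sit. The expected change is a step that the limit leaves unreadable from compound 2 to compound 3, with no direction and nothing beyond the usual scatter in this assay. For compound 3 the estimate is 24 h, within an expected range of 12 h to 48 h.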

Compound 3, half-life: > 12 h
Compound 3 ended at the assay's limit; the forecaster's own chance of this, stated with the estimate: 85%; the middle value does not contradict the limit.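

Among these compounds, no step among compound 1, compound 2 and compound 3 can be read in this assay: each entry is a limit, not a number. The compounds shown leave open how long each actually lasts, and whether configuration changes that at all.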